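Fluoro for Methyl on the Aryl Group of Compound 1

The source may report more compounds than this note shows. Statements on the series, on what has been measured and on what is new or still open speak of the compounds shown alone.

Compound 1 `C=C(Br)C(=O)Nc1cccc(-c2cn3nc(-c4ccc(C)cc4)sc3n2)c1` gives 2000 nM in a functional assay on HeLa cells (Homo sapiens) for inhibition, read by cell counting, with a stated time of 4 days (on this read-out lower numbers stand for stronger inhibition and higher numbers for weaker inhibition), the higher of the two numbers at hand. Compound 2 `C=C(Br)C(=O)Nc1cccc(-c2cn3c(-c4ccc(OC)cc4)csc3n2)c1` gives 860 nM in this assay, yet its core is arranged differently, so the two values are simply set side by side. Compound 3 `C=C(Br)C(=O)Nc1cccc(-c2cn3nc(-c4ccc(F)cc4)sc3n2)c1` carries fluoro in place of methyl on an aromatic carbon. Within the data shown here, no single-point step between measured compounds is known, and the swap exchanges one heavy atom for one, so the step of a 1.1-fold lower number from compound 1 to compound 3 (0.05 log units; within the scatter) is expected to stay within the scatter. Compound 3 is accordingly estimated at 1800 nM, with a range from 700 nM to 4500 nM.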

Compound 3, half-maximal inhibitory concentration: 870 nM
Compound 3: the middle estimate sits 2.1-fold (0.32 log units) above what was measured, and the stated range covers the measured number.
By their numbers in this assay, from the lowest: compounds 2 and 3 (each within the scatter of the next); then compound 1.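

Among these compounds, the swap of 4-methylphenyl to 4-fluorophenyl gives the only one-place step so far: in this assay it is a 2.3-fold lower number from compound 1 to compound 3 (0.36 log units; beyond the scatter). It shows that this position, on the aromatic ring and para to a large group, responds to an exchange of one heavy atom for another, though the step is modest. No measurement at hand explains this step.

Going by these compounds, how a chloro group or an amine at this position would read remains open. So does whether 4-fluorophenyl would shift the number on the core of compound 2.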